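This account rests on a few compounds, and the source may have more. Where it says the series, first, only, none or still open, it means among the compounds named here.

Measured so far:
- compound 1 `O=C(CSc1nccn1-c1ccc(Cl)cc1)Nc1ccccc1F`, in an ADME assay on MT4 cells (Homo sapiens) for cytotoxicity, read by MTT assay (on this read-out higher numbers stand for lower toxicity in this test and lower numbers for higher toxicity in this test), compound 1 gives > 345000 nM, which is a limit of the assay and not a number.
- compound 2 `COc1ccc(-n2ccnc2SCC(=O)Nc2ccccc2C)cc1`, in this assay compound 2 gives > 353000 nM, again a limit and not a number.

Within the data shown here, compound 2 thus stands at a limit in this assay, as does the one other value shown; the evidence reads the limit of > 345000 nM in this assay, at which 1 of the 2 values shown sits, and (the limit of > 353000 nM in this assay, at which 1 of the 2 values shown sits), and no step between the two measured compounds can be sized from these figures.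

Compound 3 `Cc1ccccc1NC(=O)CSc1nccn1-c1ccc(Cl)cc1` has not yet been measured in this assay. It differs from compound 2 in one place: chloro in place of methoxy on an aromatic carbon. The same chloro on the same ring is already present in compound 1.

The step in this assay is expected to be none beyond the scatter, written as a number no higher from compound 2 to compound 3 (the limit leaves the size open), because compound 1 gives > 345000 nM with that chloro in place. Compound 3 is expected to give 350000 nM in this assay, within 150000 nM to 700000 nM, most probably again reported only as a limit.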

Compound 3, half-maximal cytotoxic concentration: 160000 nM
Compound 3: middle estimate off by 2.2-fold (0.34 log units), on the high side; low and high end bracket the measured number.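

In this assay, among these compounds, compound 3 is the only one of the three compounds with a number rather than a limit, and both single changes leading to it read downward. Chloro in place of methoxy on an aromatic carbon gives an at least 2.2-fold lower number from compound 2 to compound 3 (0.34 log units; beyond the scatter), and methyl in place of fluoro on an aromatic carbon gives an at least 2.1-fold lower number from compound 1 to compound 3 (0.33 log units; beyond the scatter), so the 4-chlorophenyl of compound 1 and the methyl of compound 2 do not bring the reading off a limit on their own, while the two together in compound 3 do. Both steps are minimum sizes only, since their starting points are limits and not numbers: the limit of > 345000 nM in this assay, at which 1 of the 3 values shown sits.

From the compounds shown here alone, how far compound 3 truly lies from compound 2 stays unknown, the reading of compound 2 being a limit and not a number: the limit of > 353000 nM in this assay, at which 1 of the 3 values shown sits. Also open is whether the lower number belongs to this particular pairing of chloro and methyl, or would persist with an amine or a carboxylic acid in place of the chloro, or with a longer chain in place of the methyl.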